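This account rests on a few compounds, and the source may have more. Where it says the series, first, only, none or still open, it means among the compounds named here.

Measured so far in a functional assay on HT-29 cells (Homo sapiens) for inhibition, read by sulforhodamine B assay, with a stated time of 48 h; a higher number here means a weaker inhibitor of growth, a lower number a stronger inhibitor of growth:
compound 1 `O=C(CCl)NC(=O)Nc1cccc(OC2CCCC2)c1`: 3100 nM
compound 2 `O=C(CCl)NC(=O)Nc1cccc(OC2CCCCCC2)c1`: 6900 nM

Compound 2 has the higher of these two numbers, which makes it the weaker inhibitor of growth of the pair. Among the compounds with values here, the only measured step is a 2.2-fold higher number from compound 1 to compound 2 (0.35 log units; beyond the scatter), and it is modest. It comes with cycloheptyl in place of cyclopentyl on an oxygen on an aromatic ring.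

Compound 3 `O=C(CCl)NC(=O)Nc1cccc(Oc2ccccc2)c1` has phenyl in place of cycloheptyl at that same oxygen: phenyl in place of cycloheptyl on an oxygen on an aromatic ring. Within the data shown here, no measured compound carries an aromatic group there, so the evidence is indirect. Among the measured compounds shown here, the one guide is that compound 1, which also lacks cycloheptyl, reads 3100 nM. A small step toward a lower number in this assay is therefore expected, no larger than a 2.2-fold higher number from compound 1 to compound 2 (0.35 log units; beyond the scatter), and it may not clear the usual scatter. The estimated change is a 1.8-fold lower number from compound 2 to compound 3 (0.26 log units; within the scatter). Compound 3 is expected to read about 3800 nM, with an estimated range of 1500 nM to 10000 nM.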

Compound 3, concentration for 50% growth inhibition: 5200 nM
Compound 3: middle estimate off by 1.4-fold (0.14 log units), on the low side, and the stated range covers the measured number.
By their numbers in this assay, from the lowest: compounds 1, 3 and 2 (each within the scatter of the next, the first and the last beyond it).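

In this assay, within the data shown here, this is the first aromatic ring on this oxygen, and it leaves the reading within the scatter of both non-aromatic rings: the data show a 1.3-fold lower number from compound 2 to compound 3 (0.12 log units; within the scatter) and also a 1.7-fold higher number from compound 1 to compound 3 (0.22 log units; within the scatter) with neither step separating phenyl from the group it replaces. Exchanging either cycloalkyl ring for phenyl therefore gives no measurable change at this position, and aromatic character of the ring on the oxygen is not shown to matter for growth inhibition in these cells. The only separation among the three compounds remains the one between the two non-aromatic rings, a 2.2-fold higher number from compound 1 to compound 2 (0.35 log units; beyond the scatter) and compound 3 falls within the scatter of each of them, while no information is available on what lies behind these readings.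

The compounds shown leave open whether a ring carrying a substituent, such as a methoxyphenyl or a chlorophenyl group, would move the number beyond the scatter at this oxygen. They also leave open how an open chain such as butyl, a pyridine ring or an amine in this place would compare with the three rings seen so far.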